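The compounds below may be only part of what the source reports. "The series", "measured", "known", "first", "only" and "open" are said of these compounds alone.

Measured so far:
- compound 1 `Cc1ccc(NC(=O)c2c(NO)cc(-c3ccc(C)cc3)oc2=O)cc1`: in an ADME assay on Huh-7 cells (Homo sapiens) for cytotoxicity, read by a luciferase reporter and WST assay, with a stated time of 3 days (a lower number here means that less compound is tolerated, a higher number that more compound is tolerated), compound 1 gives > 20000 nM, a limit of the assay.
- compound 2 `CNC(=O)c1c(NO)cc(-c2ccccc2)oc1=O`: in this assay compound 2 gives > 20000 nM, a limit of the assay.
- compound 3 `CNC(=O)c1c(NO)cc(-c2ccc(F)cc2)oc1=O`: in this assay compound 3 gives > 20000 nM, a limit of the assay.

Compound 3 therefore stands at the limit, not at a number; the same holds for the whole set, since (the limit of > 20000 nM in this assay, at which 3 of the 3 values shown sit). Among the measured compounds shown here, the only single-point step among the measured compounds, a step that the two limits leave unreadable from compound 2 to compound 3, cannot be read because both ends are limits.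

Compound 4 `CNC(=O)c1c(NO)cc(-c2ccc(C)cc2)oc1=O` is the next member. Compared with compound 3 it carries the change (methyl in place of fluoro on an aromatic carbon). For the measured compounds named here, no measured step gives a readable size for a change of this kind, and the one neighbouring step is unreadable. With every value at the limit, the expectation for compound 4 in this assay is a step that the limit leaves unreadable from compound 3 to compound 4, that is, nothing beyond the scatter, and most likely a further limit rather than a number. The estimate for compound 4 is 30000 nM, with a range from 15000 nM to 100000 nM.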

Compound 4, half-maximal cytotoxic concentration: > 20000 nM
Compound 4: no number, only a limit; the forecaster's own chance of this, stated with the estimate: 85%; the middle value does not contradict the limit.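

In this assay compound 4 gives > 20000 nM, a limit of the assay. Among the compounds shown here, no step from compound 1, compound 2 or compound 3 to compound 4 can be read: the limit of > 20000 nM in this assay, at which 4 of the 4 values shown sit. Left open is where the half-maximal cytotoxic concentration of any of these four compounds lies, and whether any of these changes shifts it.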